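A few compounds are considered here, and "the series" means these few. Any claim that something is new, unique, unknown or untested is made for them only; others in the source may bear on it.

Compound 1 `CCOC(=O)CN(c1ccccc1)[C@@H]1c2cc(C#N)ccc2OC(C)(C)[C@H]1O`: > 30000 nM (a limit)
Compound 2 `CCNC(=O)CN(c1ccccc1)[C@H]1c2cc(C#N)ccc2OC(C)(C)[C@@H]1O`: > 30000 nM (a limit)
Compound 3 `CCOC(=O)C(=O)N(c1ccc(F)cc1)[C@H]1c2cc(C#N)ccc2OC(C)(C)[C@@H]1O`: 43000 nM

All three were tested in a functional assay (aorta) with Rattus norvegicus as the target; a lower number here means a stronger inhibitor, a higher number a weaker inhibitor. Compound 2 gives only a limit, > 30000 nM, and this is the limit of > 30000 nM in this assay, at which 2 of the 3 values shown sit. Compound 4 `CC1(C)Oc2ccc(C#N)cc2[C@H](N(Cc2ncco2)c2ccccc2)[C@H]1O` has 1,3-oxazol-2-yl in place of ethylcarbamoyl on a saturated chain carbon bound to a nitrogen on an aromatic ring. For the measured compounds named here, no measured pair shows a comparable change. Going by the values given here, the only number, from compound 3 at 43000 nM, is also weak, so no step beyond the scatter is expected in this assay, in either direction. The expected step is a number no higher from compound 2 to compound 4 (the limit leaves the size open). For compound 4 the estimate is 30000 nM, with an expected range of 10000 nM to 90000 nM.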

Compound 4, half-maximal inhibitory concentration: > 30000 nM
Compound 4 gave a limit, no number; the forecaster's own chance of this, stated with the estimate: 60%; the middle value lies on the limit itself.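

Compound 2 and compound 4 both give only a limit, and no step can be read between them: the limit of > 30000 nM in this assay, at which 3 of the 4 values shown sit. The compounds shown leave open how far 1,3-oxazol-2-yl and ethylcarbamoyl differ at that saturated chain carbon.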